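A few compounds are considered here, and "the series" means these few. Any claim that something is new, unique, unknown or untested is made for them only; others in the source may bear on it.

For the measured compounds named here, compound 1 `O=C1CSC(c2ccc(Cl)cc2)N1n1c(CSc2nnc(-c3ccncc3)o2)nc2ccc(Br)cc2c1=O` is one of two compounds measured in a functional assay on the whole organism (strain Charles-Foster albino) for inhibition, with Rattus norvegicus as the target, read by paw edema, at a dose of 50 mg/kg by the oral route; on this read-out higher numbers stand for more inhibition at the one dose given (going by the name of the read-out) and lower numbers for less inhibition. In this assay compound 1 gives 25.2%, while compound 2 `O=c1c2cc(Br)ccc2nc(CSc2nnc(-c3ccncc3)o2)n1/N=C/c1ccccc1` gives 19.4%. These two numbers lie within the usual scatter of each other, so neither compound can be set above the other on this read-out; compound 1 simply shares the range that both occupy.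

Compound 3 `O=C1CSC(c2ccc(O)cc2)N1n1c(CSc2nnc(-c3ccncc3)o2)nc2ccc(Br)cc2c1=O` has not yet been measured. It differs from compound 1 in one place: hydroxy in place of chloro on an aromatic carbon. Going by the values given here, no measured pair in this set shows what such a swap does on this read-out, so there is no step to lean on. The expectation is therefore a shift of a number 2.2 percentage points lower from compound 1 to compound 3 (within the scatter), a step that stays within the scatter, in no clear direction. On that basis compound 3 is estimated to give 23% in this assay, with a range from 10% to 38%.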

Compound 3, a percentage reported as inhibition, in the whole organism at one dose (the size of the read-out at that dose, not a potency): 32.7%
Beside the measured number, compound 3's estimate is 9.7 percentage points below it; measured number inside the range.
By their numbers in this assay, from the lowest: compounds 2, 1 and 3 (each within the scatter of the next, the first and the last beyond it).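

For the compounds shown here, replacing 4-chlorophenyl with 4-hydroxyphenyl gives the first direct reading of this place on the ring in this assay with a number 7.5 percentage points higher from compound 1 to compound 3 (within the scatter) as the step. That step lies within the usual scatter, so chloro and hydroxy cannot be told apart here, even though hydroxy brings a hydrogen-bond donor and a hydrogen-bond acceptor that chloro lacks. Nothing available accounts for this reading.

As far as these compounds go, whether an amine, a methoxy group or a carboxylic acid at this same place on the ring would give a step beyond the scatter remains open. Also open, from the compounds shown here alone, is whether chloro and hydroxy would still be indistinguishable at other doses, since this read-out rests on a single dose.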